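Compound 3 to compound 4: the bare phenyl

A few compounds are considered here, and "the series" means these few. Any claim that something is new, unique, unknown or untested is made for them only; others in the source may bear on it.

In a functional assay on SMMC-7721 cells (Homo sapiens) for cytotoxicity, read by MTT assay, with a stated time of 72 h (a lower number here means a stronger inhibitor, a higher number a weaker inhibitor), compound 1 `COc1cccc(C=C2C(=O)N(c3ccc(Cl)cc3)N(c3ccc(Cl)cc3)C2=O)c1` gives 30200 nM and compound 2 `COc1ccccc1C=C1C(=O)N(c2ccc(Cl)cc2)N(c2ccc(Cl)cc2)C1=O` gives 25800 nM while compound 3 `O=C1C(=Cc2ccc(F)cc2F)C(=O)N(c2ccc(Cl)cc2)N1c1ccc(Cl)cc1` gives 35800 nM in the same read-out. Compound 3 therefore stands within the scatter of both other compounds, with no meaningful order among the three.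

Compound 4 `O=C1C(=Cc2ccccc2)C(=O)N(c2ccc(Cl)cc2)N1c1ccc(Cl)cc1` carries phenyl in place of 2,4-difluorophenyl on a double-bonded chain carbon bound to a double-bonded ring carbon with the rest of the structure unchanged.

All three measured steps replace the group at this same place. They are a 1.2-fold lower number from compound 1 to compound 2 (0.07 log units; within the scatter) and a 1.2-fold higher number from compound 1 to compound 3 (0.07 log units; within the scatter) and a 1.4-fold higher number from compound 2 to compound 3 (0.14 log units; within the scatter) and each stays within the scatter. Going by the values given here, no compound with an unsubstituted phenyl has been measured yet, so this rests on the substituted examples alone.

The expected change is a 1.2-fold lower number from compound 3 to compound 4 (0.08 log units; within the scatter) and no step beyond the scatter is expected.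

For compound 4 the estimated value is 30000 nM with an expected range from 15000 nM to 60000 nM as the likely span.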

Compound 4, half-maximal inhibitory concentration: 26200 nM
Beside the measured number, compound 4's estimate is 1.1-fold (0.06 log units) above it, within the range that was stated.
By their numbers in this assay, from the lowest: compounds 2, 4, 1 and 3 (each within the scatter of the next).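

In this assay, going by these compounds alone, the unsubstituted phenyl gives the reference point that the earlier compounds lacked: losing both fluorines gives a 1.4-fold lower number from compound 3 to compound 4 (0.14 log units; within the scatter) and losing the methoxy gives a 1.0-fold higher number from compound 2 to compound 4 (0.01 log units; within the scatter) and likewise a 1.2-fold lower number from compound 1 to compound 4 (0.06 log units; within the scatter) for the other methoxyphenyl. On a double-bonded chain carbon bound to a double-bonded ring carbon, neither methoxy nor the two fluorines therefore separates from the bare phenyl, and all four compounds remain within the scatter of one another. No evidence is available on why this change leaves the read-out so flat.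

Going by these compounds, it remains open whether an amine or a carboxylic acid on this phenyl, or a longer chain in its place, would produce a step beyond the scatter. The compounds shown also leave open how changes elsewhere on the shared core would affect the read-out.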